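The source may hold more compounds than are shown below. What is called first, only, known or untested is meant among the compounds shown, and "the series" means these compounds.

Working notes on the series. Of the compounds shown here, three have numbers so far. Compound 1 `Cc1ccc(NC(=S)NC(=O)c2cn(-c3ccccc3)nc2-c2ccc(F)cc2)cc1` gives 2980 nM in a functional assay on NCI-H460 cells (Homo sapiens) for inhibition, read by CCK-8 assay, with a stated time of 48 h; a lower number here means a stronger inhibitor, a higher number a weaker inhibitor. Compound 2 `Cc1ccc(NC(=S)NC(=O)c2cn(-c3ccccc3)nc2-c2ccc(Cl)cc2)cc1` gives 3120 nM in this assay. Compound 3 `Cc1ccc(-c2nn(-c3ccccc3)cc2C(=O)NC(=S)Nc2ccc(Cl)cc2)cc1` gives 3650 nM in this assay, the highest of the three numbers, though its gaps to compound 2 and to compound 1 both sit within the scatter, so the three compounds are not told apart by these data.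

One step is measured: a 1.0-fold higher number from compound 1 to compound 2 (0.02 log units; within the scatter), a swap of one halogen for another on the aryl attached to the shared core.

Compound 4 `Cc1ccc(NC(=S)NC(=O)c2cn(-c3ccccc3)nc2-c2ccc(C)cc2)cc1` is the next one. The change is methyl in place of chloro on an aromatic carbon. Among the measured compounds shown here, no measured step puts a methyl in place of a halogen, so the only guide is the halogen swap from compound 1 to compound 2, which stayed within the scatter. On that basis the step of a 1.0-fold lower number from compound 3 to compound 4 (0.02 log units; within the scatter) is expected to stay within the scatter as well, with no direction claimed. Compound 4 is therefore estimated at 3500 nM in this assay, within 1700 nM to 7500 nM.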

Compound 4, half-maximal inhibitory concentration: 3760 nM
Beside the measured number, compound 4's estimate is 1.1-fold (0.03 log units) below it; measured number inside the range.
By their numbers in this assay, from the lowest: compounds 1, 2, 3 and 4 (each within the scatter of the next).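

In this assay, methyl in place of chloro can now be read at two places: on the (4-chlorophenyl)amino group (a 1.0-fold higher number from compound 3 to compound 4 (0.01 log units; within the scatter)) and on the aryl attached to the shared core (a 1.2-fold higher number from compound 2 to compound 4 (0.08 log units; within the scatter)), and both steps stay within the scatter. Methyl in place of fluoro on that same aryl (a 1.3-fold higher number from compound 1 to compound 4 (0.10 log units; within the scatter)) also stays within the scatter, so fluoro, chloro and methyl are not told apart there, and chloro and methyl are not told apart on the other aryl. Nothing available explains why these steps are so small.

No step shown here goes beyond the scatter, so it remains open whether either place can shift the number at all. A group of another kind at these places, such as an amine, a carboxylic acid or a longer chain, remains untested in the compounds shown, as does any substituent on the unsubstituted phenyl of the shared core.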